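Trimming the aminoethyl chain from compound 1

A few compounds are considered here, and "the series" means these few. Any claim that something is new, unique, unknown or untested is made for them only; others in the source may bear on it.

Compound 1 `Cc1ccc(NC(=O)Nc2ccc(Oc3cc(NCCN)ncn3)cc2)cc1C(F)(F)F` — > 10000 nM
Compound 2 `CC(=O)Nc1cc(Oc2ccc(NC(=O)Nc3ccc(CN4CCN(C)CC4)c(C(F)(F)F)c3)cc2)ncn1` — 50 nM

The two measured compounds stand far apart in a functional assay on BaF3 cells (Mus musculus) for inhibition, read by CCK-8 assay, with a stated time of 72 h; on this read-out higher numbers stand for weaker inhibition of growth and lower numbers for stronger inhibition of growth. For compound 1 the assay reports only a limit, > 10000 nM, so its potency is not known as a number. Compound 2 differs from compound 1 in several places at once; in this assay compound 2 gives 50 nM, and their two values show a wide gap but no single change accounts for it.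

Compound 3 `Cc1ccc(NC(=O)Nc2ccc(Oc3cc(N)ncn3)cc2)cc1C(F)(F)F` differs from compound 1 by hydrogen in place of 2-aminoethyl on a nitrogen on an aromatic ring. Going by the values given here, no pair of measured compounds differing in one place is available, so the weight of this change cannot be read from data. Compound 3 is expected to remain weak in this assay because compound 1 sits at the limit (the limit of > 10000 nM in this assay, at which 1 of the 2 values shown sits). Compound 3 is estimated at 4000 nM, within 400 nM to 20000 nM. That estimate means a step of an at least 2.5-fold lower number from compound 1 to compound 3 (0.39 log units; beyond the scatter), expected to be modest at most.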

Compound 3, concentration for 50% growth inhibition: > 10000 nM
Compound 3: only a limit was reported (the forecaster's own chance of this, stated with the estimate: 45%); middle value at least 2.5-fold (0.39 log units) away from the limit.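

Compound 3, like compound 1, gives only a limit in this assay, so the step between these two compounds cannot be read: the limit of > 10000 nM in this assay, at which 2 of the 3 values shown sit. The compounds shown leave open how much the 2-aminoethyl group on the aromatic-ring nitrogen matters for growth inhibition.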